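This account rests on a few compounds, and the source may have more. Where it says the series, first, only, none or still open, it means among the compounds named here.

Three compounds have been measured in a functional assay for inhibition of sodium/hydrogen exchanger (Oryctolagus cuniculus); on this read-out lower numbers stand for stronger inhibition and higher numbers for weaker inhibition:

Compound 1 `Cc1cc(C2CCCCC2)c(S(C)(=O)=O)cc1C(=O)N=C(N)N` gives 22 nM
Compound 2 `Cc1cc(-c2ccc(Cl)cc2Cl)c(S(C)(=O)=O)cc1C(=O)N=C(N)N` gives 42 nM
Compound 3 `Cc1cc(Oc2ccc(Cl)cc2)c(S(C)(=O)=O)cc1C(=O)N=C(N)N` gives 13 nM

Compound 3 has the lowest number of the three. Its distance from compound 1 is small, a 1.7-fold lower number from compound 1 to compound 3 (0.23 log units; within the scatter), so these two cannot be told apart. Against compound 2 the gap is real but modest, a 3.2-fold lower number from compound 2 to compound 3 (0.51 log units; beyond the scatter). The remaining pair shows a 1.9-fold higher number from compound 1 to compound 2 (0.28 log units; within the scatter). All three measured steps swap the whole group that sits on the aromatic carbon of the shared core, and the three groups give numbers that stay close together.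

Compound 4 `Cc1cc(Oc2cncc(Cl)c2)c(S(C)(=O)=O)cc1C(=O)N=C(N)N` is the next compound. It keeps the oxygen link of compound 3 and differs only in the ring beyond it: 5-chloropyridin-3-yl in place of 4-chlorophenyl on an oxygen on an aromatic ring. Going by the values given here, none of the measured steps replaces a carbon-only ring by a ring holding a hetero atom while leaving the rest of the group intact, so no measured step bears directly on this change. Given how little the three measured groups differ from one another, the expectation for compound 4 is a step of a 1.5-fold higher number from compound 3 to compound 4 (0.19 log units; within the scatter), that is, none beyond the scatter. Compound 4 is therefore estimated at 20 nM, within a range from 7 nM to 60 nM.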

Compound 4, half-maximal inhibitory concentration: 14 nM
Beside the measured number, compound 4's estimate is 1.4-fold (0.15 log units) above it; measured number inside the range.
By their numbers in this assay, from the lowest: compounds 3, 4, 1 and 2 (each within the scatter of the next, the first and the last beyond it).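

In this assay, the change from a carbon-only ring to a ring holding a nitrogen, with the oxygen link kept, gives a 1.1-fold higher number from compound 3 to compound 4 (0.03 log units; within the scatter), so at this position the 5-chloropyridin-3-yl group cannot be told apart from 4-chlorophenyl, even though it adds a hydrogen-bond acceptor. Compound 4 also stands towards the other two groups much as compound 3 does: a 3.0-fold lower number from compound 2 to compound 4 (0.48 log units; beyond the scatter) is a real but modest gap, whereas a 1.6-fold lower number from compound 1 to compound 4 (0.20 log units; within the scatter) leaves the two compounds indistinguishable. Nothing available explains why adding this hetero atom leaves the number within the scatter.

Both oxygen-linked compounds carry a chlorine on the outer ring, so the compounds shown do not tell whether that chlorine matters, and they leave open what a plain phenoxy group would give at the same place. They also leave open how far this position accepts a different kind of group, such as an amine or a carboxylic acid on the aromatic carbon in place of the ring-bearing groups seen so far.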